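The source may report more compounds than this note shows. Statements on the series, on what has been measured and on what is new or still open speak of the compounds shown alone.

Measured compounds:
- compound 1, `CC(=O)Oc1ccccc1C(=O)O[C@H]1CO[C@H]2[C@@H]1OC[C@H]2OC(=O)c1ccccc1`: 0.055 h
- compound 2, `COc1ccccc1C(=O)O[C@@H]1CO[C@H]2[C@@H]1OC[C@@H]2OC(=O)c1ccccc1OC(C)=O`: 0.0578 h
- compound 3, `CC(=O)Oc1ccccc1C(=O)O[C@H]1CO[C@H]2[C@@H]1OC[C@H]2OC(=O)c1cnoc1C`: 0.193 h

In an ADME assay on a cell-free system (plasma, Homo sapiens) for metabolic stability, with Plasma (Rattus norvegicus) as the target, read by HPLC, at pH 7.4 (on this read-out lower numbers stand for a shorter-lived compound and higher numbers for a longer-lived compound), compound 1 stands at the lowest of the three numbers; compound 2 sits within the scatter of it (a 1.1-fold higher number from compound 1 to compound 2 (0.02 log units; within the scatter)), while compound 3 lies beyond it (a 3.5-fold higher number from compound 1 to compound 3 (0.55 log units; beyond the scatter)). Compound 4, `CC(=O)Oc1ccccc1C(=O)O[C@H]1CO[C@H]2[C@@H]1OC[C@H]2OC(=O)CCO[N+](=O)[O-]`, is not yet measured. It differs from compound 1 in one place: 2-(nitrooxy)ethyl in place of phenyl on a carbonyl carbon. Within the data shown here, no measured step exchanges the phenyl for a chain; the only steps beyond the scatter both concern the 5-methyl-1,2-oxazol-4-yl (a 3.3-fold higher number from compound 2 to compound 3 (0.52 log units; beyond the scatter)), which does not bear on a 2-(nitrooxy)ethyl. The expectation for compound 4 is therefore a step of a 1.1-fold lower number from compound 1 to compound 4 (0.04 log units; within the scatter), with wide uncertainty. The half-life of compound 4 is estimated at 0.05 h, within 0.02 h to 0.15 h.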

Compound 4, half-life: 0.065 h
For compound 4 the middle estimate is 1.3-fold (0.11 log units) below the measured one, within the range that was stated.
By their numbers in this assay, from the lowest: compounds 1, 2 and 4 (each within the scatter of the next); then compound 3.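

At this carbonyl carbon, the first open chain in the series, 2-(nitrooxy)ethyl, replaces an aromatic ring with no change beyond the scatter in this assay: a 1.2-fold higher number from compound 1 to compound 4 (0.07 log units; within the scatter) and a 1.1-fold higher number from compound 2 to compound 4 (0.05 log units; within the scatter). Among the groups shown, only 5-methyl-1,2-oxazol-4-yl stands apart, with a 3.0-fold lower number from compound 3 to compound 4 (0.47 log units; beyond the scatter). No available evidence bears on the reason for this.

Going by these compounds, it remains open whether a longer chain carrying the nitrooxy group would stay level with compound 4. The same question applies to a chain ending in an amine or a carboxylic acid.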